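A few compounds are considered here, and "the series" means these few. Any claim that something is new, unique, unknown or untested is made for them only; others in the source may bear on it.

The compounds measured so far:
compound 1 `O=C1NCCN1c1ccc(S(=O)(=O)Nc2ccccc2)cc1`: 470 nM
compound 3 `CCCCOc1ccc(NS(=O)(=O)c2ccc(N3CCNC3=O)cc2)cc1`: 870 nM
Compound 2 `CC(C)(C)c1ccc(NS(=O)(=O)c2ccc(N3CCNC3=O)cc2)cc1` gives only the limit > 1000 nM, which is a limit of the assay rather than a number.

In a functional assay on MCF7 cells (Homo sapiens) for antiproliferative activity, read by sulforhodamine B assay, with a stated time of 48 h (a higher number here means a weaker inhibitor, a lower number a stronger inhibitor), compound 1 stands lowest of the two numbers, and its nearest neighbour compound 3 lies within the scatter, as a 1.9-fold higher number from compound 1 to compound 3 (0.27 log units; within the scatter) shows. Compound 2 sits at the limit of > 1000 nM in this assay, at which 1 of the 3 values shown sits. The unmeasured compound 4 `O=C1NCCN1c1ccc(S(=O)(=O)Nc2cccc(Cl)c2)cc1` differs from compound 1 by chloro in place of hydrogen on an aromatic carbon. For the measured compounds named here, the steps that bear on it, an at least 2.1-fold higher number from compound 1 to compound 2 (0.32 log units; beyond the scatter) and a 1.9-fold higher number from compound 1 to compound 3 (0.27 log units; within the scatter), both put a bulkier group onto the same ring and gave no lower numbers; chloro is far smaller, so the expected step of a 1.1-fold higher number from compound 1 to compound 4 (0.03 log units; within the scatter) is modest at most. Compound 4 is therefore estimated at 500 nM, between 200 nM and 1200 nM.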

Compound 4, half-maximal inhibitory concentration: 79 nM
Beside the measured number, compound 4's estimate is 6.3-fold (0.80 log units) above it, outside the stated range (below it).
By their numbers in this assay, from the lowest: compound 4; then compounds 1 and 3 (each within the scatter of the next). At a limit, above all of these: compound 2.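

In this assay, a 5.9-fold lower number from compound 1 to compound 4 (0.77 log units; beyond the scatter) shows that a substituent on this ring can lower the number, which neither an at least 2.1-fold higher number from compound 1 to compound 2 (0.32 log units; beyond the scatter) nor a 1.9-fold higher number from compound 1 to compound 3 (0.27 log units; within the scatter) had shown. Chloro, a single heavy atom meta to a large group, is the only change here that lowers the number beyond the scatter. None of the data shown accounts for this step.

The compounds shown leave open whether a fluoro, methyl or methoxy group at this place would do the same. They also leave open how chloro would read on another carbon of the ring.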